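This account rests on a few compounds, and the source may have more. Where it says the series, first, only, none or still open, it means among the compounds named here.

Compound 3 `CC(=O)N1CCN(c2nc(=O)c3cc(C(F)(F)F)cc([N+](=O)[O-])c3s2)CC1` carries acetyl on an amine nitrogen in a ring, and in an ADME assay on Vero cells (Chlorocebus sabaeus) for cytotoxicity, read by MTT assay, with a stated time of 72 h (on this read-out lower numbers stand for higher toxicity in this test and higher numbers for lower toxicity in this test), compound 3 gives > 125000 nM, which is a limit and not a number. Compound 1 `CSCC(=O)N1CCN(c2nc(=O)c3cc(C(F)(F)F)cc([N+](=O)[O-])c3s2)CC1` gives > 125000 nM in this assay, again a limit. Compound 2 `O=C(c1ccc(Cl)cc1)N1CCN(c2nc(=O)c3cc(C(F)(F)F)cc([N+](=O)[O-])c3s2)CC1`, which brings a ring of its own in 4-chlorophenyl, gives > 125000 nM, also a limit. Compound 3 therefore stands with the other two at the limit of > 125000 nM in this assay, at which 3 of the 3 values shown sit.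

The measured steps are a step that the two limits leave unreadable from compound 1 to compound 2, a step that the two limits leave unreadable from compound 1 to compound 3 and a step that the two limits leave unreadable from compound 2 to compound 3, so none of them offers a size to carry forward.

Compound 4 `O=c1nc(N2CCN(CC3CCCCC3)CC2)sc2c([N+](=O)[O-])cc(C(F)(F)F)cc12` differs from compound 3 in a new way: cyclohexylmethyl in place of acetyl on an amine nitrogen in a ring. Cyclohexylmethyl takes the place of acetyl, so the carbonyl that all three measured compounds hold at this place is gone, and no measured step covers that loss. The data therefore give only a loose expectation, and staying at the limit remains quite possible. Still, a fall in the number is judged the likelier direction in this assay, meaning somewhat higher toxicity.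

The modest step expected here is an at least 1.5-fold lower number from compound 3 to compound 4 (0.19 log units; that floor lies within the scatter). Compound 4 is estimated at 80000 nM, with an expected range from 20000 nM to 200000 nM.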

Compound 4, half-maximal cytotoxic concentration: > 125000 nM
Compound 4: only a limit was reported; the forecaster's own chance of this, stated with the estimate: 40%; middle value at least 1.5-fold (0.19 log units) from the limit.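

Compound 4 gives > 125000 nM in this assay, which is again a limit and not a number. Going by these compounds alone, no step from compound 1, compound 2 or compound 3 to compound 4 can be read, and all four compounds stand together: the limit of > 125000 nM in this assay, at which 4 of the 4 values shown sit. On these data alone, whether any of these groups on the amine nitrogen changes toxicity in this test remains open.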